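The source may report more compounds than this note shows. Statements on the series, on what has been measured and on what is new or still open speak of the compounds shown alone.

Measured compounds, with their values in a functional assay on HepG2 cells (Homo sapiens) for antiproliferative activity, read by sulforhodamine B assay, with a stated time of 72 h; a higher number here means a weaker inhibitor, a lower number a stronger inhibitor:

compound 1 `C[C@@H](NC(=O)OC(C)(C)C)C(=O)Nc1ccc2ncnc(Nc3ccc(F)c(Cl)c3)c2c1`, > 50000 nM, a limit of the assay and not a number
compound 2 `CC(C)[C@@H](NC(=O)OC(C)(C)C)C(=O)Nc1ccc2ncnc(Nc3ccc(F)c(Cl)c3)c2c1`, > 50000 nM, a limit of the assay and not a number
compound 3 `C[C@@H](NC(=O)OC(C)(C)C)C(=O)Nc1ccc2ncnc(Nc3cccc(C(F)(F)F)c3)c2c1`, > 50000 nM, a limit of the assay and not a number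

Every reading so far sits at the limit (the limit of > 50000 nM in this assay, at which 3 of the 3 values shown sit). The change from compound 1 to compound 2 is isopropyl in place of methyl on a saturated chain carbon bound to an amide-type nitrogen and a carbonyl carbon; its step is a step that the two limits leave unreadable from compound 1 to compound 2. The cores of compound 1 and compound 3 differ by 3-(trifluoromethyl)phenyl in place of 3-chloro-4-fluorophenyl on a nitrogen on an aromatic ring, and that step is a step that the two limits leave unreadable from compound 1 to compound 3. Compound 4 `CC(C)[C@@H](NC(=O)OC(C)(C)C)C(=O)Nc1ccc2ncnc(Nc3cccc(C(F)(F)F)c3)c2c1` is not yet measured; it differs from compound 3 by isopropyl in place of methyl on a saturated chain carbon bound to an amide-type nitrogen and a carbonyl carbon, the same change as from compound 1 to compound 2, at the same place. Set against the earlier step, the expected step here is a step that the limit leaves unreadable from compound 3 to compound 4, since both anchors rest at the limit (the limit of > 50000 nM in this assay, at which 3 of the 3 values shown sit). Compound 4 is estimated at 60000 nM in this assay, most likely reported again only as a limit.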

Compound 4, half-maximal inhibitory concentration: 4300 nM
Compound 4: middle estimate off by 14-fold (1.14 log units), on the high side; measured number outside the range, below it.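

In this assay, isopropyl in place of methyl on a saturated chain carbon bound to an amide-type nitrogen and a carbonyl carbon gives an at least 11-fold lower number from compound 3 to compound 4 (1.06 log units; beyond the scatter), and 3-(trifluoromethyl)phenyl in place of 3-chloro-4-fluorophenyl on a nitrogen on an aromatic ring gives an at least 11-fold lower number from compound 2 to compound 4 (1.06 log units; beyond the scatter). Compound 2 gives > 50000 nM, a limit of the assay and not a number, so the same isopropyl change on the core of compound 1 cannot be read, nor can the other steps among compound 1, compound 2 and compound 3. The drop is thus seen on one core only and does not show that the change carries from one core to another, with most of the set resting at the limit: the limit of > 50000 nM in this assay, at which 3 of the 4 values shown sit.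

Still open, as far as these compounds go, is whether a longer chain such as isobutyl on that chain carbon keeps the value of compound 4. Also open, from the compounds shown here alone, is what a free amine in place of the tert-butoxycarbonyl-protected amino group would give.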